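Swapping an amide for a cyclohexyl ester on the shared core

This account rests on a few compounds, and the source may have more. Where it says the series, first, only, none or still open, it means among the compounds named here.

Measured compounds:
compound 1 `CC1=C(C(=O)CC(C)C)C(c2cccs2)NC(=O)N1` gives 43%
compound 2 `CC1=C(C(=O)NC(C)C)C(c2ccoc2)NC(=O)N1` gives 3%
compound 3 `CC1=C(C(=O)NC(C)C)C(c2cccs2)NC(=O)N1` gives 40%

All three were tested in an assay on membranes from HEK293 cells for displacement of a labelled ligand from adenosine receptor A2b (Homo sapiens), read by scintillation counting, with a stated time of 30 min, tested at 1 uM; on this read-out lower numbers stand for less inhibition and higher numbers for more inhibition at the one concentration tested (going by the name of the read-out). Compound 3 stands second highest of the three numbers: its nearest neighbour is compound 1, with a number 3 percentage points lower from compound 1 to compound 3 (within the scatter); the furthest is compound 2, with a number 37 percentage points higher from compound 2 to compound 3 (beyond the scatter).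

Compound 4 `CC1=C(C(=O)OC2CCCCC2)C(c2cccs2)NC(=O)N1` has not yet been measured. It differs from compound 3 in one place: cyclohexyloxy in place of isopropylamino on a carbonyl carbon.

Within the data shown here, only one measured step touches the same place, the carbonyl carbon: going from compound 1 to compound 3 exchanged the group on that carbon and gave a number 3 percentage points lower from compound 1 to compound 3 (within the scatter). The large step from compound 2 to compound 3 concerns a different place, the saturated ring carbon, and says nothing about what happens at the carbonyl. With a single step at the carbonyl carbon, and that one within the scatter, the change to compound 4 is expected to bring no step beyond the scatter in this assay, that is, no change at the digits printed from compound 3 to compound 4 (within the scatter) is expected. Compound 4 is therefore estimated at 40%, with a range from 15% to 65%.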

Compound 4, a percentage reported as inhibition, at one concentration (the size of the read-out at that concentration, not a potency): 3%
The estimate for compound 4 lay 37 percentage points above the measured number; the measured number lies below the stated range.
By their numbers in this assay, from the lowest: compounds 2 and 4 (each within the scatter of the next); then compounds 3 and 1 (each within the scatter of the next).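

In this assay, the group on this carbonyl carbon turns out to matter: the earlier exchange between isobutyl and isopropylamino stayed within the scatter, whereas cyclohexyloxy gives a number 37 percentage points lower from compound 3 to compound 4 (beyond the scatter) and a number 40 percentage points lower from compound 1 to compound 4 (beyond the scatter). All three compounds carry the same thiophen-2-yl group and differ only at the carbonyl carbon, and the loss of the amide hydrogen cannot by itself track the drop, since compound 1 has no such hydrogen either and still stands within the scatter of compound 3. Nothing available here explains the drop.

The change brings in a new linking oxygen and a six-membered carbon ring at once, so the compounds shown leave open which of the two goes with the lower number. A cyclohexylamino group, which keeps the ring on a nitrogen, and an isopropoxy group, which keeps the small branched chain on an oxygen, would pull these two apart on the same core.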